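The source may report more compounds than this note shows. Statements on the series, on what has been measured and on what is new or still open speak of the compounds shown alone.

Measured so far, in a functional assay on Shh Light II cells (Mus musculus) for inhibition, read by a luciferase reporter; on this read-out higher numbers stand for weaker inhibition and lower numbers for stronger inhibition:
- compound 1 `O=C(Nc1ccccc1Cl)N1CCN(c2nc(-c3ccc4ccccc4n3)no2)CC1` gives 140 nM
- compound 2 `O=C(NC1CCS(=O)(=O)CC1)N1CCC(c2nc(-c3ccc4ccccc4n3)no2)CC1` gives 360 nM
- compound 3 `Cn1c(-c2noc(C3CCN(C(=O)NC4CCCCC4)CC3)n2)nc2ccccc21` gives 89 nM

Compound 2 stands highest of the three numbers in this assay. Its nearest neighbour is compound 1, whose number is lower by a margin beyond the scatter, and compound 3 lies further below it, again beyond the scatter. Compound 4 `O=C(OCc1ccccc1)N1CCC(c2nc(-c3ccc4ccccc4n3)no2)CC1` is not yet measured. It differs from compound 2 at one point: benzyloxy in place of (1,1-dioxothian-4-yl)amino on a carbonyl carbon. Going by the values given here, no measured pair shows this exact change, so the step from compound 2 to compound 4 cannot be read from a precedent. Since compound 1 and compound 3 both give lower numbers than compound 2, compound 4 is expected to land somewhat lower, by an estimated 1.8-fold lower number from compound 2 to compound 4 (0.26 log units; within the scatter), a step within the scatter. For compound 4 the estimated value is 200 nM, with a range from 70 nM to 600 nM.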

Compound 4, half-maximal inhibitory concentration: > 2500 nM
Compound 4 ended at the assay's limit; the forecaster's own chance of this, stated with the estimate: 5%; middle value at least 12-fold (1.09 log units) from the limit.
By their numbers in this assay, from the lowest: compounds 3 and 1 (each within the scatter of the next); then compound 2. At a limit, above all of these: compound 4.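

In this assay compound 4 gives > 2500 nM, which is a limit of the assay and not a number. Going by these compounds alone, putting benzyloxy on this carbonyl carbon gives an at least 6.9-fold higher number from compound 2 to compound 4 (0.84 log units; beyond the scatter), the first sign that the group at this position can change the read-out by more than the scatter. The true size of the step stays unknown, and only its lower bound can be read: the limit of > 2500 nM in this assay, at which 1 of the 4 values shown sits.

The compounds shown leave open whether the loss belongs to the oxygen link or to the benzyl part of the new group. A benzylamino group on the same carbonyl carbon would separate the two.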